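Swapping the aryl group on a triazole-linked oxime ether

This account rests on a few compounds, and the source may have more. Where it says the series, first, only, none or still open, it means among the compounds named here.

Measured compounds:
compound 1 `COc1ccc([C@@H]2C/C(=N/OCc3cn(-c4ccc(O)cc4)nn3)c3cc(CC=C(C)C)c(OC)cc3O2)cc1` — 65%
compound 2 `COc1cc2c(cc1CC1OC1(C)C)C(=O)C[C@@H](c1ccc(O)cc1)O2` — 97%

In a functional assay on HCT-116 cells (Homo sapiens) for inhibition, read by sulforhodamine B assay, with a stated time of 48 h, tested at 50 uM (a higher number here means more inhibition of growth at the concentration tested, a lower number less inhibition of growth), compound 1 gives 65%, the lower of the two numbers recorded. Compound 2 gives 97%, a number beyond the usual scatter above that of compound 1. Within the data shown here, the two compounds differ in several places at once, so their values are only two points of reference and no single step between them can be read.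

Compound 3 `COc1ccc([C@@H]2C/C(=N/OCc3cn(-c4cccnc4Cl)nn3)c3cc(CC=C(C)C)c(OC)cc3O2)cc1` is the next member of the series. It differs from compound 1 in one place: 2-chloropyridin-3-yl in place of 4-hydroxyphenyl on an aromatic nitrogen. Among the measured compounds shown here, no measured pair in this set shows the effect of such an exchange on the aromatic nitrogen of the triazole, so the direction of the step cannot be inferred from the data at hand. The step from compound 1 to compound 3 is therefore expected to be small, a number 3 percentage points lower from compound 1 to compound 3 (within the scatter), and not beyond the scatter in either direction. On that basis compound 3 is estimated to give 62% in this assay, with a range from 35% to 85% reflecting the absence of any guiding comparison.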

Compound 3, percent growth inhibition at one concentration: 47%
Estimate against measurement, compound 3: 15 percentage points above; the measured number falls inside the stated range.
By their numbers in this assay, from the lowest: compound 3; then compound 1; then compound 2.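

The aryl group on the triazole nitrogen is not a silent position: in this assay, 2-chloropyridin-3-yl in place of 4-hydroxyphenyl gives a number 18 percentage points lower from compound 1 to compound 3 (beyond the scatter) and is the first single-place change that can be read among these compounds. The count of heavy atoms stays the same across this exchange, yet the hydroxyl with its hydrogen-bond donor leaves while a ring nitrogen and a chlorine enter, so this one step bundles several changes and cannot be assigned to any one of them. Nothing available here accounts for the drop in growth inhibition.

The compounds shown leave open whether the lower number follows the loss of the hydroxyl, the arrival of the chlorine or the ring nitrogen, and a single step cannot show how the series behaves at this position more generally. An unsubstituted phenyl, a 4-aminophenyl or a pyridin-3-yl without the chlorine on the same triazole nitrogen would begin to separate these changes.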